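The compounds below may be only part of what the source reports. "The series", "measured", "known", "first", "only" and "open" are said of these compounds alone.

Going by the values given here, in a functional assay on CHO cells for agonist activity at Free fatty acid receptor 1 (Homo sapiens), read by a luciferase reporter, with a stated time of 24 h (on this read-out higher numbers stand for an effect only at larger amounts of compound and lower numbers for an effect already at smaller amounts), compound 2, with the structure `CCc1ccccc1-c1cc2cc(CCC(=O)O)ccc2[nH]1`, gives 1800 nM, the only actual number among the three measured compounds. Compound 1, `Cn1c(-c2ccccc2Br)cc2cc(CCC(=O)O)ccc21`, reaches only the limit of the assay with > 10000 nM. Compound 3, `Cn1c(-c2cccc(Cl)c2)cc2cc(CCC(=O)O)ccc21`, likewise gives a limit, > 10000 nM. Taken together, this is the limit of > 10000 nM in this assay, at which 2 of the 3 values shown sit. Among the compounds with values here, the one measured step between two compounds that differ in a single place, a step that the two limits leave unreadable from compound 1 to compound 3, can therefore be read neither in size nor in direction.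

Compound 4, `O=C(O)CCc1ccc2[nH]c(-c3ccccc3Cl)cc2c1`, is still to be measured in this assay. It differs from compound 2 by chloro in place of ethyl on an aromatic carbon. Within the data shown here, no measured step bears directly on this exchange: compound 1 and compound 3 share a core that differs from the one common to compound 2 and compound 4, and the step between them is unreadable. With nothing pointing one way, the expected step is a 1.4-fold higher number from compound 2 to compound 4 (0.14 log units; within the scatter), within the usual scatter. Compound 4 is therefore estimated at 2500 nM, with a range from 800 nM to 8000 nM.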

Compound 4, half-maximal effective concentration: 54.6 nM
For compound 4 the middle estimate is 46-fold (1.66 log units) above the measured one; measured number below the stated range.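

In this assay, going by these compounds alone, putting chloro in place of ethyl on an aromatic carbon, ortho to a large group, gives a 33-fold lower number from compound 2 to compound 4 (1.52 log units; beyond the scatter), and this is the first step that can be read. It shows that this one place on the ring matters a great deal: one chlorine atom entering where two carbon atoms leave moves the number well beyond the usual scatter. Within the data shown here, the earlier compounds could not show this, as their only step lay between two limits of the assay.

No measurement shown accounts for why this exchange moves the number so far. Going by these compounds, it also stays open whether fluoro, methoxy or trifluoromethyl would serve as well at this place, and whether chloro here would bring the core of compound 1 within the range of the assay.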